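This account rests on a few compounds, and the source may have more. Where it says the series, first, only, none or still open, it means among the compounds named here.

Compound 1 `O=C(O)CC/C=C\C[C@H]1[C@H](F)CC[C@@H]1NS(=O)(=O)c1ccc(F)cc1` and compound 2 `O=C(O)CC/C=C\CC1=CCC[C@@H]1NS(=O)(=O)c1ccc(F)cc1` share the chain and the sulfonamide but carry different cores; the difference between the two cores is not broken down here. In a functional assay on a cell-free system (plasma) for inhibition of thromboxane A2 receptor (Homo sapiens), read by turbidimetry (a lower number here means a stronger inhibitor, a higher number a weaker inhibitor), compound 1 gives 750 nM, and compound 2 gives 1300 nM. Compound 3 `O=C(O)CC/C=C\C[C@H]1[C@H](F)CC[C@@H]1NS(=O)(=O)c1ccccc1` is compound 1 with hydrogen in place of fluoro on an aromatic carbon, and in this assay compound 3 gives 2000 nM. That change gave a 2.7-fold higher number from compound 1 to compound 3 (0.43 log units; beyond the scatter). The values of compound 2 and compound 3 lie within the scatter of each other, so no order between them can be read.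

Compound 4 `O=C(O)CC/C=C\CC1=CCC[C@@H]1NS(=O)(=O)c1ccccc1` has not yet been measured. It stands to compound 2 as compound 3 stands to compound 1: hydrogen in place of fluoro on an aromatic carbon. The two places of the change are described in the same words, so this is the same change made on the other core. Among the measured compounds shown here, only one measured instance of this change exists, on the core of compound 1, and it is not known whether the core of compound 2 responds alike.

The expectation for compound 4 in this assay rests on the step from compound 1 to compound 3, and is that the step will be a 2.7-fold higher number from compound 2 to compound 4 (0.43 log units; beyond the scatter). Compound 4 is therefore estimated at 3500 nM, with the likely range from 1700 nM to 7500 nM.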

Compound 4, half-maximal inhibitory concentration: 2200 nM
Compound 4: the middle estimate sits 1.6-fold (0.20 log units) above what was measured; measured number inside the range.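

In this assay, going from 4-fluorophenyl to phenyl on the core of compound 2 gives a 1.7-fold higher number from compound 2 to compound 4 (0.23 log units; within the scatter), whereas the same change on the other core gave a 2.7-fold higher number from compound 1 to compound 3 (0.43 log units; beyond the scatter). Set side by side, the two steps cannot be told apart: the same change on two cores in this assay, a 2.7-fold higher number (0.43 log units; beyond the scatter) from compound 1 to compound 3 and a 1.7-fold higher number (0.23 log units; within the scatter) from compound 2 to compound 4, 1.6-fold (0.20 log units) apart, within the scatter of two such steps. Among the compounds shown here, this shows that the two cores are compatible with a shared response to this change, but it does not show that the change carries over with a fixed size or even that it has a real effect on the core of compound 2, as only the step on the core of compound 1 lies beyond the scatter and two instances establish no rule for the series.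

The compounds shown leave open how a chloro or a methoxy group on the same aromatic carbon would read on either core, and whether a third core would respond as these two do. They also leave open how this step would behave with an amide or a tetrazole in place of the carboxylic acid, or with a longer chain.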